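Replacing methylphenyl with a chlorophenylcarbonyl on a weak series

A few compounds are considered here, and "the series" means these few. Any claim that something is new, unique, unknown or untested is made for them only; others in the source may bear on it.

Compound 1, `Cc1ccccc1NNC(=O)c1ccc(NS(=O)(=O)c2cnc(O)nc2O)cc1`: > 20000 nM
Compound 2, `Cc1ccccc1NNC(=O)c1cccc(NS(=O)(=O)c2cnc(O)nc2O)c1`: > 20000 nM
Compound 3, `O=C(NNc1ccccc1Cl)c1ccccc1NS(=O)(=O)c1cnc(O)nc1O`: 18900 nM

These three compounds were tested in a functional assay on MDA-MB-231 cells (Homo sapiens) for antiproliferative activity, read by MTT assay, with a stated time of 24 h; a lower number here means a stronger inhibitor, a higher number a weaker inhibitor. For compound 1 the value > 20000 nM is a limit of the assay, not a number. For compound 2 the value > 20000 nM is likewise a limit. Compound 3 gives 18900 nM in this assay. Compound 1 therefore stands at the limit of > 20000 nM in this assay, at which 2 of the 3 values shown sit, so only a ceiling is known for it, not where beneath it the true figure lies.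

Compound 4, `O=C(NNC(=O)c1ccccc1Cl)c1ccc(NS(=O)(=O)c2cnc(O)nc2O)cc1`, has not yet been measured in this assay. Its structure departs from compound 1 in one place: (2-chlorophenyl)carbonyl in place of 2-methylphenyl on an amine nitrogen. Among the compounds with values here, no step between two measured compounds in this set is available, so no measured change guides the expectation. With every measured value at or near the limit, compound 4 is expected to remain a weak inhibitor as well, and the step from compound 1 to compound 4 is expected to be a number no higher from compound 1 to compound 4 (the limit leaves the size open), within the usual scatter. The value expected for compound 4 in this assay is 20000 nM, with a range from 8000 nM to 50000 nM.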

Compound 4, half-maximal inhibitory concentration: 13900 nM
The estimate for compound 4 lay 1.4-fold (0.16 log units) above the measured number; low and high end bracket the measured number.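

In this assay, placing (2-chlorophenyl)carbonyl instead of 2-methylphenyl on this amine nitrogen gives an at least 1.4-fold lower number from compound 1 to compound 4 (0.15 log units; that floor lies within the scatter), so the change leaves compound 4 with a measured value, though no real gain is established. Compound 1 gives > 20000 nM, which is a limit of the assay and not a number. The true size of the step remains unknown because the starting point is such a limit: the limit of > 20000 nM in this assay, at which 2 of the 4 values shown sit.

The chlorine and the carbonyl enter together in this one change, and the compounds shown do not separate their contributions. A plain benzoyl group or a (2-methylphenyl)carbonyl group on the same nitrogen would help to tell them apart, while an amine or a longer chain there would test whether any other group moves the value clearly beyond the scatter.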